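Acetamido for methyl on the shared anilino ring

A few compounds are considered here, and "the series" means these few. Any claim that something is new, unique, unknown or untested is made for them only; others in the source may bear on it.

Compound 3 `Cc1cccc(Nc2nccc(-c3ccccn3)n2)c1` gives 700 nM in a functional assay for inhibition, with Homo sapiens as the target (on this read-out higher numbers stand for weaker inhibition and lower numbers for stronger inhibition), the lowest of the three numbers; compound 2 `Fc1cccc(Nc2nccc(-c3ccccn3)n2)c1` gives 1000 nM and compound 1 `CCOC(=O)c1cccc(Nc2nccc(-c3ccccn3)n2)c1` gives 3000 nM. The step of a 1.4-fold lower number from compound 2 to compound 3 (0.15 log units; within the scatter) is within the scatter, whereas a 4.3-fold lower number from compound 1 to compound 3 (0.63 log units; beyond the scatter) and a 3.0-fold lower number from compound 1 to compound 2 (0.48 log units; beyond the scatter) are beyond it. Compound 4 `CC(=O)Nc1cccc(Nc2nccc(-c3ccccn3)n2)c1` carries acetamido in place of methyl on an aromatic carbon. The nearest comparison is compound 1, where ethoxycarbonyl at the same position gave the highest number; acetamido, like ethoxycarbonyl, is a larger group than methyl or fluoro, so a modest rise in the number is expected, though the donor of the acetamido has no parallel here. The step is estimated at a 2.1-fold higher number from compound 3 to compound 4 (0.33 log units; beyond the scatter). Compound 4 is therefore expected to give about 1500 nM in this assay, within 500 nM to 5000 nM.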

Compound 4, half-maximal inhibitory concentration: 300 nM
The estimate for compound 4 lay 5.0-fold (0.70 log units) above the measured number; measured number outside the range, below it.
By their numbers in this assay, from the lowest: compound 4; then compounds 3 and 2 (each within the scatter of the next); then compound 1.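

In this assay, going by these compounds alone, acetamido at this position gives the lowest number so far, with a 2.3-fold lower number from compound 3 to compound 4 (0.37 log units; beyond the scatter), a 3.3-fold lower number from compound 2 to compound 4 (0.52 log units; beyond the scatter) and a 10-fold lower number from compound 1 to compound 4 (1.00 log units; beyond the scatter). Acetamido and ethoxycarbonyl, the two largest groups here, stand at opposite ends of the order, so a larger group at this position does not by itself raise the number. Nothing measured accounts for the difference between them.

As far as these compounds go, the role of the amide hydrogen remains open. A free amine or a methanesulfonamide in this place would test how far the effect extends beyond acetamido.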